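Stripping the Substituents: Plain Phenyl on the Shared Core

A few compounds are considered here, and "the series" means these few. Any claim that something is new, unique, unknown or untested is made for them only; others in the source may bear on it.

Among the compounds with values here, in a functional assay on AGS cells (Homo sapiens) for cytotoxicity, read by MTT assay, with a stated time of 48 h (a lower number here means a stronger inhibitor, a higher number a weaker inhibitor), compound 3 `Cc1nc2c3ccccc3ccc2c2nc3c(ccc4ccccc43)c(-c3cc([N+](=O)[O-])ccc3N)c12` gives 17800 nM, the highest of the two numbers known here. Its nearest neighbour, compound 1 `Cc1nc2c3ccccc3ccc2c2nc3c(ccc4ccccc43)c(-c3ccccc3S)c12`, gives 4070 nM. Compound 2 `Cc1ccc(-c2c3ccc4ccccc4c3nc3c2c(C)nc2c4ccccc4ccc32)cc1` gives only a limit of the assay, > 80000 nM; (the limit of > 80000 nM in this assay, at which 1 of the 3 values shown sits).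

Compound 4 `Cc1nc2c3ccccc3ccc2c2nc3c(ccc4ccccc43)c(-c3ccccc3)c12` has not been measured. It differs from compound 3 by phenyl in place of 2-amino-5-nitrophenyl on an aromatic carbon. Within the data shown here, two measured steps bear on this change. Replacing 2-sulfanylphenyl by 2-amino-5-nitrophenyl gave a 4.4-fold higher number from compound 1 to compound 3 (0.64 log units; beyond the scatter), while replacing 4-methylphenyl by 2-amino-5-nitrophenyl gave an at least 4.4-fold lower number from compound 2 to compound 3 (0.65 log units; beyond the scatter); the two ends of that set differ by an at least 19-fold higher number from compound 1 to compound 2 (1.29 log units; beyond the scatter). A plain phenyl stands structurally closer to 4-methylphenyl than to either substituted ring, so compound 4 is expected to give a weaker result, a step of a 2.2-fold higher number from compound 3 to compound 4 (0.35 log units; beyond the scatter). The estimate for compound 4 is 40000 nM, within a range from 12000 nM to 150000 nM, with a real chance that only a limit is reported.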

Compound 4, half-maximal inhibitory concentration: > 80000 nM
Compound 4 ended at the assay's limit (the forecaster's own chance of this, stated with the estimate: 40%); middle value at least 2.0-fold (0.30 log units) away from the limit.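

With plain phenyl on the shared core, as with 4-methylphenyl, the reading in this assay is only a limit, so the step between compound 2 and compound 4 cannot be read: the limit of > 80000 nM in this assay, at which 2 of the 4 values shown sit.

Taking all substituents off the ring gives an at least 4.4-fold higher number from compound 3 to compound 4 (0.65 log units; beyond the scatter), and taking away the sulfanyl alone gives an at least 19-fold higher number from compound 1 to compound 4 (1.29 log units; beyond the scatter). Among these four compounds, then, a readable number appears only when the phenyl carries the sulfanyl or the amino and nitro groups, while a ring with no substituent, like the one with methyl, stays at the limit.

Going by these compounds, it remains open which of the amino and nitro groups matters in compound 3. On these data alone, it also remains open whether a hydroxyl or a carboxylic acid in place of the sulfanyl of compound 1 would keep a readable number.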